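This account rests on a few compounds, and the source may have more. Where it says the series, first, only, none or still open, it means among the compounds named here.

In a functional assay on Ehrlich cells (Mus musculus) for cytotoxicity, read by MTT assay, with a stated time of 48 h (a higher number here means a weaker inhibitor, a lower number a stronger inhibitor), compound 2 `Cc1ccc(OCC(=O)NNC(=O)c2cc3ccccc3oc2=O)c(C(=O)c2ccc(Br)cc2)c1` gives 87300 nM, the larger of the two numbers recorded so far, though its gap to compound 1 `Cc1ccc(OCC(=O)NNC(=O)c2cc3ccccc3oc2=O)c(C(=O)c2cccc(Cl)c2)c1`, which gives 64900 nM, lies within the scatter. For the measured compounds named here, the single step recorded, a 1.3-fold higher number from compound 1 to compound 2 (0.13 log units; within the scatter), did not move the number. Compound 3 `Cc1ccc(C(=O)c2cc(C)ccc2OCC(=O)NNC(=O)c2cc3ccccc3oc2=O)cc1` differs from compound 2 by methyl in place of bromo on an aromatic carbon. The only bearing comes from that earlier swap on a carbonyl carbon, which stayed within the scatter; no step beyond the scatter is therefore expected here either. Compound 3 is estimated at 80000 nM, range 35000 nM to 180000 nM, an expected step of a 1.1-fold lower number from compound 2 to compound 3 (0.04 log units; within the scatter).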

Compound 3, half-maximal inhibitory concentration: 78100 nM
For compound 3 the middle estimate is 1.0-fold (0.01 log units) above the measured one; measured number inside the range.
By their numbers in this assay, from the lowest: compounds 1, 3 and 2 (each within the scatter of the next).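

In this assay, 4-methylphenyl in place of 4-bromophenyl gives a 1.1-fold lower number from compound 2 to compound 3 (0.05 log units; within the scatter) and so stays within the scatter: at this position on the ring, methyl and bromo cannot be told apart, which the earlier halogen-only pair could not show. The step with a 1.2-fold higher number from compound 1 to compound 3 (0.08 log units; within the scatter) also stays within the scatter, so a phenyl without halogen reads the same as either halogenated one. No supporting data bear on why these numbers stay together.

Still open, as far as these compounds go, is whether anything at this position moves the number beyond the scatter. An amine, a carboxylic acid or a longer chain such as butyl in place of methyl would test that.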